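Series notes: substitution on the pyridine of compound 1

The compounds below may be only part of what the source reports. "The series", "measured", "known", "first", "only" and "open" are said of these compounds alone.

Measured so far:
compound 1 `c1cncc(N2CC[C@H]3CN[C@H]3C2)c1`, 71 nM
compound 2 `c1cncc(N2CC[C@@H]3CN[C@@H]3C2)c1`, 330 nM
compound 3 `Clc1ccc(N2CC[C@H]3CN[C@H]3C2)cn1`, 13 nM

In a functional assay on HEK293 cells for agonist activity at Neuronal acetylcholine receptor; alpha4/beta2 (Homo sapiens), read by FLIPR (on this read-out higher numbers stand for an effect only at larger amounts of compound and lower numbers for an effect already at smaller amounts), compound 1 stands second highest of the three numbers. Its mirror image compound 2 gives a 4.6-fold higher number from compound 1 to compound 2 (0.67 log units; beyond the scatter), a change attributable to the fact that compounds 1 and 2 differ only in the configuration as drawn. Going by the values given here, compound 3 shows a 5.5-fold lower number from compound 1 to compound 3 (0.74 log units; beyond the scatter), the one substitution step seen so far.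

Compound 4 `N#Cc1cncc(N2CC[C@H]3CN[C@H]3C2)c1` carries cyano in place of hydrogen on an aromatic carbon. Among the compounds with values here, no measured step involves a cyano group, so the only guide is the chloro step of compound 3, which lowered the number beyond the scatter. Compound 4 is therefore expected to show a 1.8-fold lower number from compound 1 to compound 4 (0.25 log units; within the scatter), a modest lowering if the substituent follows that step, though the size is uncertain. Compound 4 is estimated at 40 nM, with a range from 10 nM to 160 nM.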

Compound 4, half-maximal effective concentration: 1900 nM
Beside the measured number, compound 4's estimate is 48-fold (1.68 log units) below it, and the stated range ends below it.
By their numbers in this assay, from the lowest: compound 3; then compound 1; then compound 2; then compound 4.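

In this assay, cyano on an aromatic carbon two atoms from the ring nitrogen gives a 27-fold higher number from compound 1 to compound 4 (1.43 log units; beyond the scatter) and so marks this position or group as poorly tolerated. The chloro step, a 5.5-fold lower number from compound 1 to compound 3 (0.74 log units; beyond the scatter) and sits elsewhere on the ring, runs the other way, so substitution on this ring has no single direction, and group and place cannot be separated here. Nothing available accounts for the size of the cyano step.

As far as these compounds go, whether the rise belongs to cyano itself or to any group at this position remains open. A methyl or methoxy group on the same carbon would separate the two.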